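Trading Trifluoromethyl for Chloro in Compound 1

The source may hold more compounds than are shown below. What is called first, only, known or untested is meant among the compounds shown, and "the series" means these compounds.

Within the data shown here, in a functional assay with Cavia porcellus as the target (a higher number here means that more compound is needed for the effect, a lower number that less compound is needed), compound 1 `COC(=O)c1c(C)[nH]c(C)c1C(=O)c1ccccc1C(F)(F)F` gives 4840 nM as the lower of the two numbers known so far. Compound 2 `COC(=O)c1c(C)[nH]c(C)c1C(=O)c1ccccc1F` gives 70000 nM and carries fluoro in place of trifluoromethyl on an aromatic carbon. Compound 3 `COC(=O)c1c(C)[nH]c(C)c1C(=O)c1ccccc1Cl` instead has chloro in place of trifluoromethyl on an aromatic carbon. Among the measured compounds shown here, the only measured step bearing on this change is large (a 14-fold higher number from compound 1 to compound 2 (1.16 log units; beyond the scatter)), so a higher number is expected for compound 3, though with only this one step as a guide, a smaller rise is assumed. The expected step is moderate (a 3.1-fold higher number from compound 1 to compound 3 (0.49 log units; beyond the scatter)). Compound 3 is estimated at 15000 nM (from 5000 nM to 50000 nM).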

Compound 3, half-maximal effective concentration: 14000 nM
Beside the measured number, compound 3's estimate is 1.1-fold (0.03 log units) above it; the measured number falls inside the stated range.
By their numbers in this assay, from the lowest: compound 1; then compound 3; then compound 2.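

In this assay chloro lands in the middle at this position, with a 2.9-fold higher number from compound 1 to compound 3 (0.46 log units; beyond the scatter) but also a 5.0-fold lower number from compound 2 to compound 3 (0.70 log units; beyond the scatter) in the same series. The position therefore separates the two single-atom groups, fluoro and chloro, from each other as well as from trifluoromethyl, and all three gaps lie beyond the scatter. Nothing available explains this order.

As far as these compounds go, whether bromo or methoxy at this position would give a lower number than compound 1 stays open. So does whether the same order would hold on a different core.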